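Dropping the Ring Halogen: From Compound 3 to Compound 4

The source may hold more compounds than are shown below. What is called first, only, known or untested is meant among the compounds shown, and "the series" means these compounds.

Measured so far:
- compound 1, `O=C(/C=C/c1ccc(CN2C(=O)/C(=C3\Nc4ccccc4\C3=N/O)c3cc(Br)ccc32)cc1)NO`: 9 nM
- compound 2, `O=C(/C=C/c1ccc(CN2C(=O)/C(=C3\Nc4ccccc4\C3=N/O)c3cc(F)ccc32)cc1)NO`: 8 nM
- compound 3, `O=C(/C=C/c1ccc(CN2C(=O)/C(=C3\Nc4ccccc4\C3=N/O)c3cc(Cl)ccc32)cc1)NO`: 7 nM

In a functional assay on NCI-H23 cells (Homo sapiens) for cytotoxicity, read by colorimetric assay (on this read-out lower numbers stand for stronger inhibition and higher numbers for weaker inhibition), compound 3 gives 7 nM, the lowest of the three numbers, yet its gaps to compound 2 and to compound 1 both lie within the scatter, so the three compounds cannot be told apart on this read-out. Compound 4, `O=C(/C=C/c1ccc(CN2C(=O)/C(=C3\Nc4ccccc4\C3=N/O)c3ccccc32)cc1)NO`, differs from compound 3 in one place: hydrogen in place of chloro on an aromatic carbon. The measured steps all concern swaps of one halogen for another: a 1.1-fold lower number from compound 1 to compound 2 (0.05 log units; within the scatter), a 1.3-fold lower number from compound 1 to compound 3 (0.11 log units; within the scatter), a 1.1-fold lower number from compound 2 to compound 3 (0.06 log units; within the scatter). None of them removes the group entirely, so they bear on the new step only indirectly; what they show is that the choice of halogen at this position barely moves the number. On that basis the step to hydrogen is also expected to be small in this assay, though the untested nature of a full removal calls for a wider range. Compound 4 is expected to give 9 nM, with a range from 4 nM to 22 nM. The step this estimate implies, a 1.3-fold higher number from compound 3 to compound 4 (0.11 log units; within the scatter), is expected to stay within the scatter.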

Compound 4, half-maximal inhibitory concentration: 9 nM
Beside the measured number, compound 4's estimate shows no gap at the digits printed; measured number inside the range.
By their numbers in this assay, from the lowest: compounds 3, 2, 1 and 4 (each within the scatter of the next).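

Taking the halogen off entirely changes nothing that can be resolved in this assay (a 1.3-fold higher number from compound 3 to compound 4 (0.11 log units; within the scatter)) and the same holds against the other two halogens (a 1.1-fold higher number from compound 2 to compound 4 (0.05 log units; within the scatter)) and (no change at the digits printed from compound 1 to compound 4 (within the scatter)). The earlier compounds shown here only showed that one halogen could stand in for another, whereas these steps show that this aromatic carbon can carry plain hydrogen with the number staying within the scatter of all three halogen compounds. For these four compounds, then, a halogen at this position is not needed for the cytotoxicity seen on these cells. Nothing available explains why this position behaves so flatly.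

Still open, on these data alone, is whether a methoxy group, an amine or a carboxylic acid on the same aromatic carbon would also leave the number unmoved. Also open, as far as these compounds go, is whether this flat picture would hold on any other cell line.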